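This account rests on a few compounds, and the source may have more. Where it says the series, first, only, none or still open, it means among the compounds named here.

Measured compounds in a functional assay on MIA PaCa-2 cells (Homo sapiens) for inhibition, read by MTT assay, with a stated time of 72 h; a higher number here means a weaker inhibitor, a lower number a stronger inhibitor:
compound 1 `Nc1ncn(C/C=C2\OC(=O)C(OCc3ccccc3)=C2OCc2ccccc2)c(=O)n1`, 920 nM
compound 2 `O=C1O/C(=C\Cn2c(=O)[nH]c(=O)[nH]c2=O)C(OCc2ccccc2)=C1OCc1ccccc1`, 37900 nM
compound 3 `O=C1O[C@H]([C@@H](O)Cn2c(=O)[nH]c(=O)[nH]c2=O)C(OCc2ccccc2)=C1OCc1ccccc1`, a limit of the assay and not a number: > 100000 nM

Compound 2 and compound 1 share one core and differ in one place: a group of 8 heavy atoms (3 carbon, 4 nitrogen, 1 oxygen; one six-membered aromatic ring with 3 hetero atoms) in place of a group of 9 heavy atoms (3 carbon, 3 nitrogen, 3 oxygen; one six-membered aromatic ring with 3 hetero atoms), on a saturated chain carbon bound to a double-bonded chain carbon. In this assay the step is large, a 41-fold lower number from compound 2 to compound 1 (1.61 log units; beyond the scatter). Compound 3 carries another core; the difference between the core of compound 2 and the core of compound 3 is not broken down here. Compound 3 sits at the limit of > 100000 nM in this assay, at which 1 of the 3 values shown sits.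

Compound 4 `Nc1ncn(C[C@H](O)[C@H]2OC(=O)C(OCc3ccccc3)=C2OCc2ccccc2)c(=O)n1` is not yet measured. It stands to compound 3 as compound 1 stands to compound 2: a group of 8 heavy atoms (3 carbon, 4 nitrogen, 1 oxygen; one six-membered aromatic ring with 3 hetero atoms) in place of a group of 9 heavy atoms (3 carbon, 3 nitrogen, 3 oxygen; one six-membered aromatic ring with 3 hetero atoms), on a saturated chain carbon, two bonds along the chain from an oxygen on a saturated carbon and a saturated ring carbon. The two places are not the same word for word. In compound 2 the change sits on a saturated chain carbon bound to a double-bonded chain carbon; in compound 3 it sits on a saturated chain carbon, two bonds along the chain from an oxygen on a saturated carbon and a saturated ring carbon. It is therefore the same kind of change, not the same change.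

The step from compound 3 to compound 4 is expected at an at least 5.0-fold lower number from compound 3 to compound 4 (0.69 log units; beyond the scatter), set beside the measured 41-fold lower number from compound 2 to compound 1 (1.61 log units; beyond the scatter). This expectation rests on compound 2 and compound 1 alone, and its anchor is loose because compound 3 gives only (the limit of > 100000 nM in this assay, at which 1 of the 3 values shown sits). Compound 1 at 920 nM marks what the stronger core reaches. Compound 4 is expected near 20000 nM, between 3000 nM and 100000 nM.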

Compound 4, half-maximal inhibitory concentration: 71700 nM
Compound 4: the middle estimate sits 3.6-fold (0.55 log units) below what was measured, within the range that was stated.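

In this assay, placing the group of 8 heavy atoms in the position of the group of 9 heavy atoms, on a saturated chain carbon, two bonds along the chain from an oxygen on a saturated carbon and a saturated ring carbon, gives an at least 1.3-fold lower number from compound 3 to compound 4 (0.14 log units; that floor lies within the scatter), and on the other core the same kind of change gives a 41-fold lower number from compound 2 to compound 1 (1.61 log units; beyond the scatter). This shows that the large step on the core of compound 1 has no measured counterpart of matching size on the core of compound 4, yet it does not show that the change carries over less well, nor that it carries over fully: the same change on two cores in this assay, a 41-fold lower number (1.61 log units; beyond the scatter) from compound 2 to compound 1 and an at least 1.3-fold lower number (0.14 log units; that floor lies within the scatter) from compound 3 to compound 4; the limit leaves it open whether they differ The reading on the core of compound 4 is only a floor, as compound 3 gives a limit of the assay and not a number: the limit of > 100000 nM in this assay, at which 1 of the 4 values shown sits.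

The compounds shown leave open how a longer chain, or an amine or a carboxylic acid in place of the six-membered aromatic ring, would read on either core. From the compounds shown here alone, with one pair on each core and one end of the second pair at a limit, whether the size of this step depends on the core also stays open.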